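This account rests on a few compounds, and the source may have more. Where it says the series, first, only, none or still open, it means among the compounds named here.

Compound 2, `COc1cccc(NC2=CC(=O)c3c(nc4n3[C@H]3OC[C@@H](O)[C@H]3OC4)C2=O)c1`, is one of three anilino-substituted analogues sharing a common core. In a functional assay on MGC-803 cells (Homo sapiens) for inhibition, read by sulforhodamine B assay (on this read-out lower numbers stand for stronger inhibition and higher numbers for weaker inhibition), compound 2 gives 1790 nM, the highest of the three numbers, though its gap to either neighbour lies within the scatter: compound 3, `COc1cccc(NC2=CC(=O)c3nc4n(c3C2=O)[C@H]2OC[C@@H](O)[C@H]2OC4)c1`, gives 1780 nM, and compound 1, `Cc1ccc(NC2=CC(=O)c3nc4n(c3C2=O)[C@H]2OC[C@@H](O)[C@H]2OC4)cc1`, gives 1420 nM. For the measured compounds named here, the only single-point step among the measured compounds, a 1.3-fold higher number from compound 1 to compound 3 (0.10 log units; within the scatter), shows that exchanging one aryl group for another on the amine nitrogen left the read-out essentially unmoved.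

Compound 4, `O=C1C(Nc2ccccc2F)=CC(=O)c2c1nc1n2[C@H]2OC[C@@H](O)[C@H]2OC1`, has not yet been measured. It differs from compound 2 by 2-fluorophenyl in place of 3-methoxyphenyl on an amine nitrogen. Going by the values given here, the one relevant precedent, the exchange of aryl groups between compound 1 and compound 3, stayed within the scatter, so a further aryl exchange at the same nitrogen is expected to move the number little, with no direction favoured. The step from compound 2 to compound 4 is therefore expected to be a 1.0-fold higher number from compound 2 to compound 4 (0.00 log units; within the scatter). Compound 4 is accordingly estimated at 1800 nM, with a range from 850 nM to 3800 nM.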

Compound 4, half-maximal inhibitory concentration: 2000 nM
Estimate against measurement, compound 4: 1.1-fold (0.05 log units) below; the range from low to high includes it.
By their numbers in this assay, from the lowest: compounds 1, 3, 2 and 4 (each within the scatter of the next).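

In this assay, the exchange of 3-methoxyphenyl for 2-fluorophenyl on the amine nitrogen gives a 1.1-fold higher number from compound 2 to compound 4 (0.05 log units; within the scatter), so a second aryl exchange also stays within the scatter, this time on the core of compound 2 rather than that of compound 1. The step also replaces the methoxy-bearing ring, with its hydrogen-bond acceptor, by a fluorine-bearing ring without one, and the number still does not leave the scatter, so across these four compounds no aryl group on this nitrogen stands apart. No measurement here accounts for this flat read-out. As far as these compounds go, what remains open is whether anything other than a substituted phenyl at this nitrogen, such as a cyclohexyl group, a pyridine ring or a benzyl group, would move the number beyond the scatter. A phenyl ring carrying a carboxylic acid or an amine is equally untested by the compounds shown.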